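The source may hold more compounds than are shown below. What is called first, only, known or untested is meant among the compounds shown, and "the series" means these compounds.

Measured compounds:
- compound 1 `O=C(NCc1cn(Cc2ccc(F)cc2)nn1)c1cn(-c2ccccc2)nc1-c1ccccc1` gives 9600 nM in a functional assay on MIA PaCa-2 cells (Homo sapiens) for antiproliferative activity, read by sulforhodamine B assay, with a stated time of 48 h; a lower number here means a stronger inhibitor of growth, a higher number a weaker inhibitor of growth
- compound 2 `COc1ccc(Cn2cc(CNC(=O)c3cn(-c4ccccc4)nc3-c3ccccc3)nn2)cc1` gives 10200 nM in this assay
- compound 3 `COc1cc(Cn2cc(CNC(=O)c3cn(-c4ccccc4)nc3-c3ccccc3)nn2)cc(OC)c1OC` gives 1000 nM in this assay

Among these three numbers compound 1 stands second highest. Compound 2 sits close to it, with a 1.1-fold higher number from compound 1 to compound 2 (0.03 log units; within the scatter), a change that stays within the scatter. Compound 3 lies well apart, with a 9.6-fold lower number from compound 1 to compound 3 (0.98 log units; beyond the scatter), and the related move a 10-fold lower number from compound 2 to compound 3 (1.01 log units; beyond the scatter) points the same way.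

Compound 4 `O=C(NCc1cn(Cc2ccc(F)cc2)nn1)c1cn(-c2ccccc2)nc1-c1ccc(Cl)cc1` differs from compound 1 in one place: chloro in place of hydrogen on an aromatic carbon. This position is untouched by any of the measured steps. All three of them alter the group on the saturated chain carbon bound to the aromatic nitrogen, on the other side of the shared core, so none of them speaks directly to a chloro on the phenyl of the core. The only lesson at hand is that a single small substituent swap on an aromatic ring, as from compound 1 to compound 2, gave no step beyond the scatter. On that basis compound 4 is expected to show a 1.3-fold lower number from compound 1 to compound 4 (0.11 log units; within the scatter), a step within the scatter. The estimate for compound 4 in this assay is therefore 7500 nM, with a range from 2500 nM to 22000 nM.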

Compound 4, concentration for 50% growth inhibition: 1990 nM
Estimate against measurement, compound 4: 3.8-fold (0.58 log units) above; the measured number lies below the stated range.
By their numbers in this assay, from the lowest: compounds 3 and 4 (each within the scatter of the next); then compounds 1 and 2 (each within the scatter of the next).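

In this assay the change from phenyl to 4-chlorophenyl brings a 4.8-fold lower number from compound 1 to compound 4 (0.68 log units; beyond the scatter) and shows that a single chlorine atom on this aromatic carbon, para to a large group, is enough to move the number beyond the scatter. Among the earlier steps, only the one to the 3,4,5-trimethoxyphenyl group had done so, at a different place on the shared core, so this is a second place where a change registers in growth inhibition. Nothing measured here explains why the chloro has this effect.

On these data alone, it remains open whether this step is particular to chloro or would also appear with a bromo, an amine or a carboxylic acid on the same carbon. Also open, as far as these compounds go, is how the chloro and the 3,4,5-trimethoxyphenyl group would act together in one molecule.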